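Adding a Methyl to the Pyridine of Compound 2

The source may hold more compounds than are shown below. What is called first, only, known or untested is meant among the compounds shown, and "the series" means these compounds.

Of the compounds shown here, three built on a shared core have been measured in an assay for inhibition of protein disulfide-isomerase (Homo sapiens), with a stated time of 1 h; on this read-out higher numbers stand for weaker inhibition and lower numbers for stronger inhibition. Compound 1 `Oc1c(C(Nc2ccccn2)c2ccccc2Cl)ccc2cccnc12` gives 500 nM. Compound 2 `Cc1ccc(C)c(C(Nc2ccccn2)c2ccc3cccnc3c2O)c1` gives 730 nM, and compound 3 `Cc1cc(C)c(C(Nc2ccccn2)c2ccc3cccnc3c2O)c(C)c1` gives 190 nM. Compound 2 and compound 1 sit within the scatter of each other, a 1.5-fold higher number from compound 1 to compound 2 (0.16 log units; within the scatter), whereas compound 3 lies beyond it, a 3.8-fold lower number from compound 2 to compound 3 (0.58 log units; beyond the scatter); the step of a 2.6-fold lower number from compound 1 to compound 3 (0.42 log units; beyond the scatter) also lies beyond the scatter.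

Compound 4 `Cc1ccnc(NC(c2cc(C)ccc2C)c2ccc3cccnc3c2O)c1` has not yet been measured. It differs from compound 2 at the pyridin-2-yl group: methyl in place of hydrogen on an aromatic carbon. Cut one bond further out, pyridin-2-yl becomes 4-methylpyridin-2-yl, and (pyridin-2-yl)amino becomes (4-methylpyridin-2-yl)amino.

Within the data shown here, none of the measured steps touches this part of the molecule; all three vary the aryl group on the saturated chain carbon. The data therefore give no guide to the size or direction of a change at this place, and no step beyond the scatter is expected. Compound 4 is estimated to show no change at the digits printed from compound 2 to compound 4 (within the scatter), with an expected value of 730 nM, ranging from 300 nM to 1800 nM.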

Compound 4, half-maximal inhibitory concentration: > 40000 nM
Compound 4: no number, only a limit; the forecaster's own chance of this, stated with the estimate: 2%; middle value at least 54-fold (1.73 log units) away from the limit.
By their numbers in this assay, from the lowest: compound 3; then compounds 1 and 2 (each within the scatter of the next). At a limit, above all of these: compound 4.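

Compound 4 gives only a limit in this assay: the limit of > 40000 nM in this assay, at which 1 of the 4 values shown sits.

Among these compounds, the pyridin-2-yl group, which no earlier step touched, turns out to be highly sensitive to change: one methyl on the aromatic carbon opposite the ring nitrogen gives an at least 54-fold higher number from compound 2 to compound 4 (1.73 log units; beyond the scatter). That outruns the largest step among the aryl groups, a 3.8-fold lower number from compound 2 to compound 3 (0.58 log units; beyond the scatter), so a single added carbon here can matter more than swapping the whole aryl group did.

The compounds shown leave open whether only methyl does this or whether any group on this carbon would, such as a fluorine, a methoxy or a hydroxyl. As far as these compounds go, it also remains unknown whether 4-methylpyridin-2-yl would have the same effect alongside the 2,4,6-trimethylphenyl group of compound 3, or what a methyl on another carbon of this ring would do.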